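A Missing Value and an Iodine Swap

The compounds below may be only part of what the source reports. "The series", "measured", "known", "first", "only" and "open" are said of these compounds alone.

- Compound 1 `COc1cccc(-n2cc(COc3c(/C=C\C(=O)O)ccc(OC)c3CC=C(C)C)nn2)c1`: 42700 nM
- Compound 2 `COc1ccc(/C=C\C(=O)O)c(OCc2cn(-c3cccc(C#N)c3)nn2)c1CC=C(C)C`: "not determined" (no result reported)

In a functional assay on A549 cells (Homo sapiens) for cytotoxicity, read by MTT assay, with a stated time of 24 h (a lower number here means a stronger inhibitor, a higher number a weaker inhibitor), compound 1 gives 42700 nM. Among the compounds with values here, this is the only number available for the series so far. Compound 2 has no number to stand on, as its entry reads "not determined" (no result reported). It therefore offers no direct starting point for judging its close relative, compound 3 `COc1ccc(/C=C\C(=O)O)c(OCc2cn(-c3ccccc3I)nn2)c1CC=C(C)C`, which is still to be tested.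

The structural change is 2-iodophenyl in place of 3-cyanophenyl on an aromatic nitrogen. It places 2-iodophenyl in place of 3-cyanophenyl on an aromatic nitrogen, and the rest of the molecule stays the same. Compound 1 shares that remaining structure and differs only in the group on this nitrogen, which makes it the nearest measured guide.

With no value for compound 2, the true size of this step cannot be read from the data. The expectation is that compound 3 will land within the scatter of compound 1 at 42700 nM, with no shift expected in either direction. For compound 3, the estimated value is 40000 nM, with an expected range from 15000 nM to 100000 nM.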

Compound 3, half-maximal inhibitory concentration: 2200 nM
The estimate for compound 3 lay 18-fold (1.26 log units) above the measured number; the measured number lies below the stated range.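

In this assay, the group on the aromatic nitrogen proves to matter a great deal: putting 2-iodophenyl in place of 3-methoxyphenyl, with the rest of the molecule unchanged, gives a 19-fold lower number from compound 1 to compound 3 (1.29 log units; beyond the scatter), a step well beyond the usual scatter of repeat measurements. Compound 2 has no reported result, so the step from it to compound 3 cannot be read, and the comparison with 3-cyanophenyl stays empty. The size of the change is clear, but no measurement here accounts for it.

The swap from compound 1 to compound 3 alters both the atom on the phenyl ring and the name's ring position, so these compounds cannot show whether the lower number belongs to the iodine itself or to where it sits. An unsubstituted phenyl group, or bromine in place of the iodine on the same ring, would help separate these two readings and show how much of the step depends on iodine in particular.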